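The compounds below may be only part of what the source reports. "The series", "measured", "known", "first", "only" and "open" are said of these compounds alone.

Measured in an ADME assay on TERT-RPE1 cells (Homo sapiens) for cytotoxicity, read by MTT assay, with a stated time of 72 h; on this read-out higher numbers stand for weaker inhibition and lower numbers for stronger inhibition:
compound 1 `COc1ccc(/C=C2/CN(C)/C(=N/c3ccc(Br)cc3)S2)cc1` gives 61300 nM
compound 2 `COc1ccc(/C=C2\S/C(=N\c3ccc(C(C)(C)C)cc3)N(C)C2=O)cc1` gives 46700 nM
compound 3 `COc1ccc(/C=C2\S/C(=N\c3ccc(Br)cc3)N(C)C2=O)cc1` gives > 100000 nM (a limit of the assay, not a number)

Compound 3 sits at the limit of > 100000 nM in this assay, at which 1 of the 3 values shown sits, and so has a limit rather than a number. The change to compound 4 `COc1ccc(/C=C2\S/C(=N\c3ccccc3)N(C)C2=O)cc1` is hydrogen in place of bromo on an aromatic carbon, hydrogen in place of bromo, or 4-bromophenyl to phenyl. One measured step involves this aromatic carbon: an at least 2.1-fold higher number from compound 2 to compound 3 (0.33 log units; beyond the scatter), a lower bound that ends in bromo, not hydrogen. It gives no direct size for the new change, so no step beyond the scatter is expected in this assay and the expected step is an at least 1.1-fold lower number from compound 3 to compound 4 (0.04 log units; that floor lies within the scatter), with a further limit quite possible. The estimate for compound 4 is 90000 nM, with an expected range of 40000 nM to 200000 nM.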

Compound 4, half-maximal inhibitory concentration: > 100000 nM
Compound 4: no number, only a limit; the forecaster's own chance of this, stated with the estimate: 50%; middle value at least 1.1-fold (0.04 log units) from the limit.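

In this assay, compound 4 gives > 100000 nM, a limit of the assay and not a number, so hydrogen at this aromatic carbon, like bromo, yields no measured value. Of the three groups shown here, only tert-butyl gives a number, and replacing it with hydrogen gives an at least 2.1-fold higher number from compound 2 to compound 4 (0.33 log units; beyond the scatter). The step from bromo to hydrogen cannot be read, with both compounds at the same limit: the limit of > 100000 nM in this assay, at which 2 of the 4 values shown sit.

As far as these compounds go, whether an amine or a carboxylic acid at this aromatic carbon would give a number in this assay remains open. From the compounds shown here alone, how far compound 3 and compound 4 lie beyond the limit also remains open.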